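The source may hold more compounds than are shown below. What is called first, only, known or untested is meant among the compounds shown, and "the series" means these compounds.

Measured compounds and their results:

Compound 1, `Cc1cc(=O)n(-c2ccc(Br)cc2F)nc1C(=O)Nc1ccc(Oc2ncnc3[nH]ccc23)c(F)c1`: 6120 nM
Compound 2, `Cc1cc(=O)n(-c2ccc(Br)cc2F)nc1C(=O)Nc1ccc(Oc2ncnc3c2ccn3C)cc1`: 47300 nM
Compound 3, `Cc1cc(=O)n(-c2ccccc2OC(F)(F)F)nc1C(=O)Nc1ccc(Oc2ncnc3c2ccn3C)c(F)c1`: > 60000 nM

The read-out throughout is a functional assay on A549 cells (Homo sapiens) for cytotoxicity, read by MTT assay, with a stated time of 72 h; on this read-out higher numbers stand for weaker inhibition and lower numbers for stronger inhibition. Compound 1 gives 6120 nM in this assay. Compound 2, which carries the same 4-bromo-2-fluorophenyl group but a different heteroaromatic part and no fluorine on the middle ring, gives 47300 nM. For compound 3 the result of > 60000 nM is a limit of the assay and not a number, so compound 3 stands at the weak end of what this assay can report; one of the three values shown sits at this limit (the limit of > 60000 nM in this assay, at which 1 of the 3 values shown sits). Within the data shown here, no pair of the measured compounds differs in a single place, so no measured step is available.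

Compound 4, `Cc1cc(=O)n(-c2ccc(Br)cc2F)nc1C(=O)Nc1ccc(Oc2ncnc3c2ccn3C)c(F)c1`, is not yet measured. It differs from compound 3 in one place: 4-bromo-2-fluorophenyl in place of 2-(trifluoromethoxy)phenyl on an aromatic nitrogen. The same 4-bromo-2-fluorophenyl group is present in compound 1 and in compound 2, whose values in this assay both lie inside the measurable range. The expected step from compound 3 to compound 4 is therefore towards stronger inhibition, and is estimated as an at least 2.0-fold lower number from compound 3 to compound 4 (0.30 log units; that floor lies within the scatter). Compound 4 is expected to give about 30000 nM, with a plausible range from 10000 nM to 90000 nM.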

Compound 4, half-maximal inhibitory concentration: 14400 nM
The estimate for compound 4 lay 2.1-fold (0.32 log units) above the measured number; low and high end bracket the measured number.
By their numbers in this assay, from the lowest: compound 1; then compound 4; then compound 2. At a limit, above all of these: compound 3.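

In this assay, placing 4-bromo-2-fluorophenyl instead of 2-(trifluoromethoxy)phenyl on the aromatic nitrogen gives an at least 4.1-fold lower number from compound 3 to compound 4 (0.61 log units; beyond the scatter), which moves this part of the series into the measurable range. The true size of that step remains unknown, since the result for compound 3 is a limit of the assay and not a number, which makes the printed step a floor: the limit of > 60000 nM in this assay, at which 1 of the 4 values shown sits.

With the 4-bromo-2-fluorophenyl group held constant, two single changes can now be read, both beyond the usual scatter: fluoro in place of hydrogen on an aromatic carbon gives a 3.3-fold lower number from compound 2 to compound 4 (0.52 log units; beyond the scatter), and methyl in place of hydrogen on an aromatic nitrogen gives a 2.4-fold higher number from compound 1 to compound 4 (0.37 log units; beyond the scatter).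

Among these compounds, each of these changes is seen in only one pair, so it remains open whether either would have the same size or direction with a different group on the other aromatic nitrogen. The compounds shown also leave open how a chlorine in place of the bromine, or an ethyl group or a longer chain in place of the methyl, would read in this assay.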